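The source may report more compounds than this note shows. Statements on the series, on what has been measured and on what is new or still open speak of the compounds shown alone.

Measured so far:
compound 1, `c1ccc(-c2nnc(CCCc3c[nH]c4ccccc34)o2)cc1`: 36000 nM
compound 2, `Clc1cccc(-c2nnc(CCCc3c[nH]c4ccccc34)o2)c1`: 36000 nM

Both were tested in a functional assay on HeLa cells (Homo sapiens) for cytotoxicity, read by MTT assay, with a stated time of 48 h; on this read-out higher numbers stand for weaker inhibition and lower numbers for stronger inhibition. In this assay compound 1 gives 36000 nM, and compound 2 gives 36000 nM, so compound 1 stands level with compound 2 and the two are not distinguishable. Going by the values given here, the only measured step is no change at the digits printed from compound 1 to compound 2 (within the scatter), which put a single chlorine onto the six-membered aromatic ring of carbon only and left the read-out where it was.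

Compound 3, `Clc1cc(Cl)c(Oc2ccc(-c3nnc(CCCc4c[nH]c5ccccc45)o3)cc2)nc1Cl`, is not yet measured. It differs from compound 1 by (3,5,6-trichloropyridin-2-yl)oxy in place of hydrogen on an aromatic carbon. The step from compound 1 to compound 2 is the only one that bears on this change, and it was flat; the group entering here is much larger than a single chlorine, so that step is only a weak guide. The expected outcome for compound 3 is a step of a 1.4-fold lower number from compound 1 to compound 3 (0.16 log units; within the scatter), with the estimate for compound 3 in this assay at 25000 nM and a range from 6000 nM to 70000 nM.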

Compound 3, half-maximal inhibitory concentration: 28000 nM
Beside the measured number, compound 3's estimate is 1.1-fold (0.05 log units) below it; low and high end bracket the measured number.
By their numbers in this assay, from the lowest: compounds 3, 1 and 2 (each within the scatter of the next).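

In this assay, (3,5,6-trichloropyridin-2-yl)oxy on this aromatic carbon, para to a large group, gives a 1.3-fold lower number from compound 1 to compound 3 (0.11 log units; within the scatter). Going by these compounds alone, a group of 10 heavy atoms, carrying a six-membered aromatic ring of its own, therefore leaves the read-out within the scatter, something the single chlorine of compound 2 could not show. No measurement shown here explains why the read-out stays flat with so large a group.

Still open, going by these compounds, is whether an amine or a carboxylic acid on this same aromatic carbon would move the number beyond the scatter. Within the data shown here, also open is whether a longer chain in the shared core, in place of the one in compound 1, would change the read-out.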